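A few compounds are considered here, and "the series" means these few. Any claim that something is new, unique, unknown or untested is made for them only; others in the source may bear on it.

Compound 1, `COc1cccc(N2CCN(C(=O)c3oc(C)nc3-c3ccccc3F)CC2)c1`, in a functional assay on HL-60 cells (Homo sapiens) for inhibition, read by MTT assay, with a stated time of 72 h (a higher number here means a weaker inhibitor, a lower number a stronger inhibitor), gives 56.1 nM.
Compound 2, `COc1cc(OC)cc(N2CCN(C(=O)c3oc(C)nc3-c3ccccc3F)CC2)c1`, in this assay gives 10.3 nM.
Compound 3, `COc1cc(OC)cc(N2CCN(C(=O)c3oc(C)nc3-c3ccc(F)cc3)CC2)c1`, in this assay gives 38.5 nM.

Compound 4, `COc1cccc(N2CCN(C(=O)c3oc(C)nc3-c3ccc(F)cc3)CC2)c1`, has not been measured. It comes from compound 3 by one change, (hydrogen in place of methoxy on an aromatic carbon). The same change has already been made once among the measured compounds, from compound 2 to compound 1: hydrogen in place of methoxy on an aromatic carbon. That step moved the number by a 5.4-fold higher number from compound 2 to compound 1 (0.74 log units; beyond the scatter). The place of the change is described in the same words in both pairs, so the two changes are the same.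

The cores of compound 3 and compound 2 differ in one spot, (4-fluorophenyl in place of 2-fluorophenyl on an aromatic carbon), which gave a 3.7-fold higher number from compound 2 to compound 3 (0.57 log units; beyond the scatter).

Within the data shown here, with only one measured example of the change, the expectation for compound 4 rests on it alone. Among the measured compounds shown here, from compound 3 to compound 4 a step of about a 4.9-fold higher number from compound 3 to compound 4 (0.69 log units; beyond the scatter) is expected, close to the one from compound 2 to compound 1, because that earlier step was a 5.4-fold higher number from compound 2 to compound 1 (0.74 log units; beyond the scatter). Compound 4 is therefore estimated at 190 nM in this assay, most likely between 75 nM and 480 nM.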

Compound 4, half-maximal inhibitory concentration: 112 nM
Compound 4: middle estimate off by 1.7-fold (0.23 log units), on the high side; the range from low to high includes it.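

Taking one methoxy off the 3,5-dimethoxyphenyl group raises the number again, with a 2.9-fold higher number from compound 3 to compound 4 (0.46 log units; beyond the scatter), and this step agrees with the earlier one: the same change on two cores in this assay, a 5.4-fold higher number (0.74 log units; beyond the scatter) from compound 2 to compound 1 and a 2.9-fold higher number (0.46 log units; beyond the scatter) from compound 3 to compound 4, 1.9-fold (0.27 log units) apart, within the scatter of two such steps.
Moving the fluorine gives a 2.0-fold higher number from compound 1 to compound 4 (0.30 log units; within the scatter), and although this step is small, it does not differ from its earlier counterpart: the same change on two cores in this assay, a 3.7-fold higher number (0.57 log units; beyond the scatter) from compound 2 to compound 3 and a 2.0-fold higher number (0.30 log units; within the scatter) from compound 1 to compound 4, 1.9-fold (0.27 log units) apart, within the scatter of two such steps.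
Among these compounds, both changes therefore carry over between these cores in this assay, but each comparison rests on only two pairs, so this does not show that the steps would hold on a different core, nor does it explain why they occur.

The compounds shown leave open whether the methoxy group matters as such, since an ethoxy group, a hydroxy group or an amine at that place could give a different step. They also leave open how a chlorine atom in place of the fluorine would behave on either core.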